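Pyrazole substituent change in the amide series

This account rests on a few compounds, and the source may have more. Where it says the series, first, only, none or still open, it means among the compounds named here.

Among the compounds with values here, compound 1 `Cc1n[nH]c(C)c1-c1cncc(-c2ccc(C(N)=O)c(OC(C)C)c2)c1` gives 33 nM in an assay on cells for inhibition of MAP kinase-interacting serine/threonine-protein kinase 1 (Homo sapiens), read by mobility shift assay, with stated times of 10 min and 60 min, in the presence of a further agent that is not named here (on this read-out higher numbers stand for weaker inhibition and lower numbers for stronger inhibition), the lowest of the two numbers so far. Within the data shown here, compound 2 `NC(=O)c1ccc(-c2cccnc2)cc1` gives 8800 nM in this assay; no single-change step links these two, their values simply stand far apart. Compound 3 `CC(C)Oc1cc(-c2cncc(-c3c[nH]nc3C3CC3)c2)ccc1C(N)=O` carries the change (3-cyclopropyl-1H-pyrazol-4-yl in place of 3,5-dimethyl-1H-pyrazol-4-yl on an aromatic carbon), 3-cyclopropyl-1H-pyrazol-4-yl in place of 3,5-dimethyl-1H-pyrazol-4-yl on an aromatic carbon. Among the measured compounds shown here, with no comparable step measured, nothing beyond the scatter is expected in this assay for this change. Compound 3 is therefore estimated at 35 nM, between 12 nM and 110 nM, a step of a 1.1-fold higher number from compound 1 to compound 3 (0.03 log units; within the scatter).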

Compound 3, half-maximal inhibitory concentration: 130 nM
Beside the measured number, compound 3's estimate is 3.7-fold (0.57 log units) below it; measured number above the stated range.
By their numbers in this assay, from the lowest: compound 1; then compound 3; then compound 2.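

At this position, two atoms from the ring nitrogen, the substituents on the pyrazole matter: in this assay, 3-cyclopropyl-1H-pyrazol-4-yl in place of 3,5-dimethyl-1H-pyrazol-4-yl gives a 3.9-fold higher number from compound 1 to compound 3 (0.60 log units; beyond the scatter) and so costs some inhibition. The pyrazole ring itself is kept in this change, so the shift comes from its substituents alone. No available measurement accounts for the shift.

Going by these compounds, it remains open whether the shift follows from losing the 3,5-dimethyl pattern or from adding the cyclopropyl ring. A pyrazole bearing a single methyl or an ethyl group would separate the two.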